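From thiazolyl to fluoropyridinyl on the aryl ether

The source may hold more compounds than are shown below. What is called first, only, known or untested is meant among the compounds shown, and "the series" means these compounds.

In an ADME assay on the whole organism (plasma, Rattus norvegicus) for protein binding, using cassette dosing, at a dose of 1 mg/kg (a higher number here means a larger unbound share of the compound, a lower number a smaller unbound share), compound 2 (`C[C@@H](Cn1c(=O)[nH]/c(=N\c2ccc(Oc3nccs3)cc2)n(Cc2ccc(Cl)cc2)c1=O)C(=O)O`) gives 0.006 as its reading. Compound 1 (`Cc1ccc(Cn2c(=O)n(CC(C)(C)C(=O)O)c(=O)[nH]/c2=N\c2ccc(OC(C)C)c(Cl)c2)cc1`) gives 0.01 and sits within the usual scatter of compound 2. Compound 3 (`Cc1ccc(Cn2c(=O)n(C[C@H](C)C(=O)O)c(=O)[nH]/c2=N\c2ccc(OC(C)C)c(Cl)c2)cc1`) gives 0.014 and stands beyond that scatter from compound 2, with the larger unbound share.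

Compound 4 (`C[C@@H](Cn1c(=O)[nH]/c(=N\c2ccc(Oc3cccc(F)n3)cc2)n(Cc2ccc(Cl)cc2)c1=O)C(=O)O`) differs from compound 2 in one place (6-fluoropyridin-2-yl in place of 1,3-thiazol-2-yl on an oxygen on an aromatic ring) where 6-fluoropyridin-2-yl stands in place of 1,3-thiazol-2-yl on an oxygen on an aromatic ring. Among the measured compounds shown here, the only measured step available is a 1.4-fold higher number from compound 1 to compound 3 (0.15 log units; within the scatter) and it lies within the scatter. That step concerns a saturated chain carbon bound to an aromatic nitrogen, not the group on the oxygen, so it bears on the new change only loosely and nothing measured here tests that change directly. Taking that small step as the sole guide, no shift beyond the scatter is expected in this assay for the new change. The expected step is a 1.2-fold lower number from compound 2 to compound 4 (0.08 log units; within the scatter) and it stays within the scatter. Compound 4 is expected at 0.005 within an estimated range of 0.002 to 0.012 in this reading.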

Compound 4, unbound fraction: 0.007
For compound 4 the middle estimate is 1.4-fold (0.15 log units) below the measured one; the range from low to high includes it.
By their numbers in this assay, from the lowest: compounds 2, 4, 1 and 3 (each within the scatter of the next, the first and the last beyond it).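

In this assay, among the compounds shown here, the step of a 1.2-fold higher number from compound 2 to compound 4 (0.07 log units; within the scatter) gives the first direct reading at this place, on an oxygen on an aromatic ring, and shows that 6-fluoropyridin-2-yl can stand in place of 1,3-thiazol-2-yl with the unbound fraction remaining within the scatter. For the compounds shown here, the only earlier step concerned a saturated chain carbon bound to an aromatic nitrogen, so this exchange of a five-membered aromatic ring with 2 hetero atoms for a six-membered aromatic ring with 1 hetero atom gives a second place of change, and neither single step lies beyond the scatter. Nothing available here explains this result.

The compounds shown leave open whether an unsubstituted phenyl or a pyrimidin-2-yl on the same oxygen would also stay within the scatter of compound 2, since only two aromatic rings are compared there. On these data alone, all of them also carry a carboxylic acid, so how a primary amide or a tetrazole in its place would read in this assay remains unknown.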